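A few compounds are considered here, and "the series" means these few. Any claim that something is new, unique, unknown or untested is made for them only; others in the source may bear on it.

Compound 1 `COc1cc(-c2nnc3n2NC(c2ccco2)C(C(=O)c2cccs2)S3)cc(OC)c1OC` stands at the low end of the three numbers at hand: in a functional assay on HepG2 cells (Homo sapiens) for cytotoxicity, read by MTT assay, with a stated time of 48 h (on this read-out lower numbers stand for stronger inhibition and higher numbers for weaker inhibition), compound 1 gives 64100 nM. Compound 2 `COc1cc(-c2nnc3n2NC(c2ccco2)C(C(=O)c2ccc(Cl)cc2)S3)cc(OC)c1OC` gives 78600 nM in this assay, and compound 3 `COc1cc(-c2nnc3n2NC(c2ccco2)C(C(=O)c2ccccc2)S3)cc(OC)c1OC` gives 90900 nM, with steps of a 1.2-fold higher number from compound 1 to compound 2 (0.09 log units; within the scatter), a 1.4-fold higher number from compound 1 to compound 3 (0.15 log units; within the scatter) and a 1.2-fold higher number from compound 2 to compound 3 (0.06 log units; within the scatter), none beyond the scatter. Compound 4 `COc1cc(-c2nnc3n2NC(c2ccco2)C(C(=O)c2ccco2)S3)cc(OC)c1OC` differs from compound 1 in one place: furan-2-yl in place of thiophen-2-yl on a carbonyl carbon. The two steps that exchange the group on the carbonyl carbon, a 1.2-fold higher number from compound 1 to compound 2 (0.09 log units; within the scatter) and a 1.4-fold higher number from compound 1 to compound 3 (0.15 log units; within the scatter), both stayed within the scatter, so no step beyond it is expected for this exchange either, and the estimate for compound 4 is 70000 nM with a range of 35000 nM to 140000 nM, an expected step of a 1.1-fold higher number from compound 1 to compound 4 (0.04 log units; within the scatter).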

Compound 4, half-maximal inhibitory concentration: > 100000 nM
Compound 4: no number, only a limit; the forecaster's own chance of this, stated with the estimate: 10%; middle value at least 1.4-fold (0.15 log units) from the limit.
By their numbers in this assay, from the lowest: compounds 1, 2 and 3 (each within the scatter of the next). At a limit, above all of these: compound 4.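

Compound 4 gives no number in this assay, only a limit: the limit of > 100000 nM in this assay, at which 1 of the 4 values shown sits. Among the four groups shown on this carbonyl carbon, furan-2-yl alone reaches that limit, which the thiophen-2-yl, phenyl and 4-chlorophenyl compounds do not. Its steps are only floors, an at least 1.5-fold higher number from compound 1 to compound 4 (0.19 log units; that floor lies within the scatter), an at least 1.2-fold higher number from compound 2 to compound 4 (0.10 log units; that floor lies within the scatter) and an at least 1.1-fold higher number from compound 3 to compound 4 (0.04 log units; that floor lies within the scatter), so this change is not shown to go beyond the scatter, though it may.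

Going by these compounds, the real value behind the limit of compound 4 stays open. So does whether a cyclohexyl group or an amine on this carbonyl carbon would shift the read-out beyond the scatter.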